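Removing the methyl from compound 1: an expected small step

The source may hold more compounds than are shown below. What is called first, only, known or untested is meant among the compounds shown, and "the series" means these compounds.

Three analogues of a shared thiosemicarbazide core have been measured in a functional assay on GLC82 cells (Homo sapiens) for cytotoxicity, read by MTT assay, with a stated time of 72 h; on this read-out lower numbers stand for stronger inhibition and higher numbers for weaker inhibition. Compound 1 `COc1cc2ncnc(NNC(=S)NC(=O)c3ccccc3C)c2cc1OC` gives 21500 nM. Compound 2 `O=C(NC(=S)NNc1ncnc2ccccc12)c1ccc(C(F)(F)F)cc1` gives 12200 nM, and compound 3 `O=C(NC(=S)NNc1ncnc2ccccc12)c1cccc(Cl)c1` gives 3240 nM. Among these three, compound 1 carries the highest number; its value and that of compound 2 sit within the scatter of each other, so no order can be read between them, whereas compound 3 stands clearly apart with a lower number. Among the compounds with values here, compounds 2 and 3 differ from compound 1 in more than one place, so no single step connects them to it.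

Compound 4 `COc1cc2ncnc(NNC(=S)NC(=O)c3ccccc3)c2cc1OC` has not yet been measured. It differs from compound 1 only in hydrogen in place of methyl on an aromatic carbon. Within the data shown here, no measured pair shows the effect of this change on the shared core, so the expectation rests on its small size alone. The author expects the step of a 1.2-fold lower number from compound 1 to compound 4 (0.08 log units; within the scatter) to fall within the usual scatter, in either direction. For compound 4 the estimate in this assay is 18000 nM, with a range from 6000 nM to 50000 nM.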

Compound 4, half-maximal inhibitory concentration: 6550 nM
Estimate against measurement, compound 4: 2.7-fold (0.44 log units) above, within the range that was stated.
By their numbers in this assay, from the lowest: compound 3; then compounds 4, 2 and 1 (each within the scatter of the next, the first and the last beyond it).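

Within the data shown here, the step from 2-methylphenyl to phenyl is the first comparison on the shared core that changes only one place, and in this assay it gives a 3.3-fold lower number from compound 1 to compound 4 (0.52 log units; beyond the scatter) on the same core. The methyl on this aromatic carbon, ortho to a large group, therefore matters to the read-out: the change is modest but lies beyond the scatter, which compounds 2 and 3, differing from compound 1 in more than one place, could not show. Nothing at hand bears on what lies behind this step.

As far as these compounds go, whether other groups at this place, such as a chlorine, a methoxy or an ethyl, would give numbers like those of compound 1 or compound 4 remains open. So does whether the same change would give a similar step on the core of compounds 2 and 3, which lacks the methoxy groups.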